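This account rests on a few compounds, and the source may have more. Where it says the series, first, only, none or still open, it means among the compounds named here.

Three compounds have been measured in a functional assay on the whole organism (strain albino) for inhibition, with Rattus norvegicus as the target, read by paw edema, with stated times of 30 min and 3 h, at a dose of 100 mg/kg by the oral route; on this read-out higher numbers stand for more inhibition at the one dose given (going by the name of the read-out) and lower numbers for less inhibition:

compound 1 `CC(Br)C(=O)Nc1ccc(C(=O)/C=C/c2ccc(Cl)cc2)cc1`: 59%
compound 2 `O=C(COCc1c(-c2ccccc2)no[n+]1[O-])Nc1ccc(C(=O)/C=C/c2ccc(Cl)cc2)cc1`: 66%
compound 3 `COc1ccc(/C=C/C(=O)c2ccc(NC(=O)COCc3c(-c4ccccc4)no[n+]3[O-])cc2)cc1`: 56%

Compound 3 holds the lowest of the three numbers, yet its gaps to compound 1 and to compound 2 both lie within the usual scatter, so the three cannot be told apart. Compound 4 `O=C(COCc1c(-c2ccccc2)no[n+]1[O-])Nc1ccc(C(=O)/C=C/c2ccco2)cc1` differs from compound 3 by furan-2-yl in place of 4-methoxyphenyl on a double-bonded chain carbon bound to a double-bonded chain carbon. Among the measured compounds shown here, only one measured step bears on this part of the molecule, a number 10 percentage points lower from compound 2 to compound 3 (within the scatter), and it was within the scatter. For the measured compounds named here, no measured step shows one ring exchanged for another, so nothing points to a shift beyond the scatter. The step of a number 2 percentage points higher from compound 3 to compound 4 (within the scatter) is therefore expected to be small. Compound 4 is estimated at 58%, in the range 45% to 70%.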

Compound 4, a percentage reported as inhibition, in the whole organism at one dose (the size of the read-out at that dose, not a potency): 59%
Compound 4: middle estimate off by 1 percentage points, on the low side; measured number inside the range.
By their numbers in this assay, from the lowest: compounds 3, 1, 4 and 2 (each within the scatter of the next).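

In this assay, among the compounds shown here, the earlier compounds showed only one group on the phenyl ring exchanged for another, while this result shows the whole ring exchanged at this place on the double-bonded chain carbon. Furan-2-yl in place of 4-methoxyphenyl gives a step within the scatter (a number 3 percentage points higher from compound 3 to compound 4 (within the scatter)), and furan-2-yl in place of 4-chlorophenyl does too (a number 7 percentage points lower from compound 2 to compound 4 (within the scatter)), so this smaller five-membered ring cannot be told apart from either six-membered one. No measurement offers an explanation for this. Still open, from the compounds shown here alone, is how an amine, a carboxylic acid or a longer chain at this place would read out.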